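Hydroxy in Place of Methyl on the Aryl Ring

The compounds below may be only part of what the source reports. "The series", "measured", "known", "first", "only" and "open" are said of these compounds alone.

Compound 1 `O=C(/C=C(O)/C=C/c1cccc(O)c1)c1cc(Cl)ccc1O`: 62.4%
Compound 2 `Cc1cccc(/C=C2\CCC/C(=C\c3ccccc3)C2=O)c1`: 47.9%

Of the compounds shown here, two have been measured in an assay on isolated protein for inhibition of Alpha glucosidase (Homo sapiens), with stated times of 5 min and 15 min, tested at 50 uM; a higher number here means more inhibition at the concentration tested (going by the name of the read-out), a lower number less inhibition. Compound 1 gives 62.4%, while compound 2 gives 47.9%, the lower of the two numbers, with a gap to compound 1 beyond the usual scatter. Compound 3 `O=C1/C(=C/c2ccccc2)CCC/C1=C\c1cccc(O)c1` is not yet measured; it differs from compound 2 in one place: hydroxy in place of methyl on an aromatic carbon. Since compound 1 also carries a 3-hydroxyphenyl group and gives 62.4%, a moderate rise in this assay is expected, although the two cores differ. The step from compound 2 to compound 3 is estimated as a number 8.1 percentage points higher from compound 2 to compound 3 (within the scatter). Compound 3 is therefore expected to give 56%, in a range of 36% to 74%.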

Compound 3, a percentage reported as inhibition, at one concentration (the size of the read-out at that concentration, not a potency): 65.1%
The estimate for compound 3 lay 9.1 percentage points below the measured number; measured number inside the range.
By their numbers in this assay, from the lowest: compound 2; then compounds 1 and 3 (each within the scatter of the next).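

With the core held constant, the change from 3-methylphenyl to 3-hydroxyphenyl can be read directly: in this assay it gives a number 17.2 percentage points higher from compound 2 to compound 3 (beyond the scatter). Compound 1 also carries a 3-hydroxyphenyl group, but on a different core, so it could not isolate this change. Nothing at hand explains the rise, which rests on this single pair.

Going by these compounds, it remains open whether a methoxy group or an amine in the same place would give a similar number. On these data alone, it is also open whether the same change on the second aromatic ring would do so.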